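Nitro for trifluoromethyl, repeated on a second core

The compounds below may be only part of what the source reports. "The series", "measured", "known", "first", "only" and "open" are said of these compounds alone.

Of the compounds shown here, three in the set have been measured in an assay on isolated protein for inhibition of Amine oxidase [flavin-containing] B (Homo sapiens), read by Amplex Red, with a stated time of 15 min; on this read-out lower numbers stand for stronger inhibition and higher numbers for weaker inhibition. Compound 1 `CC(=O)c1ccc(OCc2ccc([N+](=O)[O-])cc2)cc1` gives 96.5 nM. Compound 2 `CC(=O)c1ccc(OCc2ccc(C(F)(F)F)cc2)cc1` gives 77.8 nM. Compound 3 `CC(=O)c1cccc(OCc2cccc(C(F)(F)F)c2)c1` gives 21.2 nM, the lowest number of the three, and its steps to compound 2 and to compound 1 both lie beyond the scatter. Compound 4 `CC(=O)c1cccc(OCc2cccc([N+](=O)[O-])c2)c1` has not yet been measured in this assay.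

Compound 1 differs from compound 2 by nitro in place of trifluoromethyl on an aromatic carbon and that change made a 1.2-fold higher number from compound 2 to compound 1 (0.09 log units; within the scatter). Compound 3 and compound 2 have the same atoms joined differently; the difference between the two cores is not broken down here. Compound 4 differs from compound 3 by nitro in place of trifluoromethyl on an aromatic carbon. The entering group sits meta to a large group in compound 4 but para to a large group in compound 1, so the change is of the same kind, not the same.

The expected step is a 1.2-fold higher number from compound 3 to compound 4 (0.09 log units; within the scatter), because a 1.2-fold higher number from compound 2 to compound 1 (0.09 log units; within the scatter) stayed within the scatter, and only the setting of the group differs. Compound 4 is therefore estimated at 26 nM in this assay, with a likely range from 12 nM to 60 nM.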

Compound 4, half-maximal inhibitory concentration: 114 nM
For compound 4 the middle estimate is 4.4-fold (0.64 log units) below the measured one; measured number above the stated range.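

In this assay, nitro in place of trifluoromethyl does not behave as a constant step across the two cores: the same change on two cores in this assay, a 1.2-fold higher number (0.09 log units; within the scatter) from compound 2 to compound 1 and a 5.4-fold higher number (0.73 log units; beyond the scatter) from compound 3 to compound 4, 4.3-fold (0.64 log units) apart, beyond the scatter of two such steps

On the second core the change gives a 5.4-fold higher number from compound 3 to compound 4 (0.73 log units; beyond the scatter), so the step read on the first core is a poor guide to its size elsewhere in this series. This does not show why the two steps part, since two pairs cannot separate the place of the entering group on its ring from the way the rest of the core is joined, and it supports no rule for cores beyond these two.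

The compounds shown leave open whether a nitrile, a chlorine or a methoxy group in the same place would track trifluoromethyl or nitro on each core. Also open, going by these compounds, is whether an amine or a carboxylic acid there would widen or narrow the gap between the cores.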